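This account rests on a few compounds, and the source may have more. Where it says the series, first, only, none or still open, it means among the compounds named here.

Measured so far:
compound 1 `O=C(Nc1ccc(Cl)cc1)C1CCCN(C(=O)c2cccc([N+](=O)[O-])c2)C1`: 0%
compound 2 `COC(=O)c1cccc(NC(=O)C2CCCN(C(=O)c3cc(C(F)(F)F)cc(C(F)(F)F)c3)C2)c1`: 0%

In an ADME assay on PC-3 cells (Homo sapiens) for cytotoxicity, read by WST assay, tested at 100 uM (a lower number here means less inhibition, a higher number more inhibition at the concentration tested (going by the name of the read-out)), compound 1 gives 0% and compound 2 gives 0%; the two read level at the digits shown, within the scatter. Going by the values given here, no pair differing in one place has been measured, so no step size is known. Compound 3 `Cc1nc(-c2cccc(C(=O)N3CCCC(C(=O)Nc4ccc(Cl)cc4)C3)c2)cs1` departs from compound 1 by 2-methyl-1,3-thiazol-4-yl in place of nitro on an aromatic carbon. With nothing in the series pointing away from the level shared by compound 1 and compound 2, the step of a number 4 percentage points higher from compound 1 to compound 3 (within the scatter) is expected to stay within the scatter. Compound 3 is estimated at 4%, in the range 0% to 22%.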

Compound 3, a percentage reported as inhibition, at one concentration (the size of the read-out at that concentration, not a potency): 1%
Compound 3: middle estimate off by 3 percentage points, on the high side, within the range that was stated.
By their numbers in this assay, from the lowest: compounds 1, 2 and 3 (each within the scatter of the next).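

In this assay, going by these compounds alone, 2-methyl-1,3-thiazol-4-yl in place of nitro on an aromatic carbon, meta to a large group, gives a number 1 percentage points higher from compound 1 to compound 3 (within the scatter) and is the first step known. At this position, a five-membered aromatic ring with 2 hetero atoms can therefore replace nitro with the read-out staying within the scatter. No measurement available here explains this outcome. Open, as far as these compounds go, is whether an amine or a carboxylic acid at this position would move the read-out, and whether any position elsewhere on the core of compound 1 responds differently.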